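From Diethylcarbamoyl to Methyl-Oxadiazole on the Shared Core

The source may report more compounds than this note shows. Statements on the series, on what has been measured and on what is new or still open speak of the compounds shown alone.

Of the compounds shown here, three on the shared core have been measured in a functional assay on BXPC-3 cells (Homo sapiens) for inhibition, read by MTT assay, with a stated time of 7 days; a higher number here means a weaker inhibitor, a lower number a stronger inhibitor. Compound 1 `CCN(CC)C(=O)[C@@H]1CCCN(S(=O)(=O)c2ccc(S(=O)(=O)N(CC)CC)cc2)C1` gives 10500 nM and stands at the highest number of the three, although compound 3 lies within the scatter of it. Compound 2 `CCN(CC)S(=O)(=O)c1ccc(S(=O)(=O)N2CCC[C@@H](C(=O)NC3CN(C(=O)OC(C)(C)C)C3)C2)cc1` gives 1800 nM, and compound 3 `CCN(CC)S(=O)(=O)c1ccc(S(=O)(=O)N2CCC[C@@H](C(=O)NC3CN(C(=O)NC(C)(C)C)C3)C2)cc1` gives 10100 nM. The measured steps all keep the carbonyl and alter only the group on it: a 5.8-fold lower number from compound 1 to compound 2 (0.77 log units; beyond the scatter), a 1.0-fold lower number from compound 1 to compound 3 (0.02 log units; within the scatter) and a 5.6-fold higher number from compound 2 to compound 3 (0.75 log units; beyond the scatter).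

Compound 4 `CCN(CC)S(=O)(=O)c1ccc(S(=O)(=O)N2CCC[C@@H](c3nc(C)no3)C2)cc1` is not yet measured. It differs from compound 1 in that (3-methyl-1,2,4-oxadiazol-5-yl in place of diethylcarbamoyl on a saturated ring carbon). Within the data shown here, none of the measured steps removes the diethylcarbamoyl group entirely, so they bear on this change only indirectly: they show that altering the group on the carbonyl carbon moves the number from no change to a modest gain, and never to a loss. On that footing a step of at most modest size is expected in this assay, with the direction uncertain and a result within the scatter of compound 1 quite possible. Compound 4 is therefore estimated at 7000 nM, within a range of 2000 nM to 25000 nM, which would mean a 1.5-fold lower number from compound 1 to compound 4 (0.18 log units; within the scatter).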

Compound 4, half-maximal inhibitory concentration: 2900 nM
Estimate against measurement, compound 4: 2.4-fold (0.38 log units) above, within the range that was stated.
By their numbers in this assay, from the lowest: compounds 2 and 4 (each within the scatter of the next); then compounds 3 and 1 (each within the scatter of the next).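

In this assay, among these compounds, the exchange of diethylcarbamoyl for 3-methyl-1,2,4-oxadiazol-5-yl gives a 3.6-fold lower number from compound 1 to compound 4 (0.56 log units; beyond the scatter) and so shows that the carbonyl on this saturated ring carbon can go entirely without any loss, whereas the earlier steps changed only the group on it. Compound 4 also places its number within the scatter of compound 2, so a gain of this kind on the shared core does not depend on the (1-(tert-butoxycarbonyl)azetidin-3-yl)amino group, and it comes here with one atom fewer than the group that leaves. No measurement at hand says why the number falls on this change.

The compounds shown leave open whether the gain belongs to the 1,2,4-oxadiazole ring itself or to the methyl on it, which an ethyl group, a hydrogen or a cyclopropyl group at that place on the ring would help to separate. They also leave open how a 1,3,4-oxadiazole, a carboxylic acid or a primary amide on the same ring carbon would compare with the 3-methyl-1,2,4-oxadiazol-5-yl group.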